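The source may report more compounds than this note shows. Statements on the series, on what has been measured and on what is new or still open speak of the compounds shown alone.

Measured so far:
compound 1 `CNC(=O)c1cc(Oc2ccc(NC(=O)c3nn(-c4cccc(F)c4)c(=O)cc3C)cc2F)ccn1` gives 9540 nM in a functional assay on A549 cells (Homo sapiens) for cytotoxicity, read by MTT assay, with a stated time of 72 h; on this read-out lower numbers stand for stronger inhibition and higher numbers for weaker inhibition.
compound 2 `Cc1cc(=O)n(-c2ccccc2OC(F)(F)F)nc1C(=O)Nc1ccc(Oc2ncnc3sccc23)c(F)c1` shows only a limit in this assay: > 40000 nM.

Compound 2 therefore sits at the limit of > 40000 nM in this assay, at which 1 of the 2 values shown sits, so no number is known for it. Compound 3 `Cc1cc(=O)n(-c2cccc(F)c2)nc1C(=O)Nc1ccc(Oc2ncnc3sccc23)c(F)c1` differs from compound 2 in one place: 3-fluorophenyl in place of 2-(trifluoromethoxy)phenyl on an aromatic nitrogen, on an aromatic nitrogen of a six-membered aromatic ring with 2 nitrogen. Going by the values given here, no measured step shows what this change does. Compound 1 carries the same 3-fluorophenyl group on a different core and gives 9540 nM in this assay. For compound 3 a move toward stronger inhibition is expected, an at least 2.6-fold lower number from compound 2 to compound 3 (0.42 log units; beyond the scatter). Compound 3 is estimated at 15000 nM, between 4000 nM and 50000 nM.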

Compound 3, half-maximal inhibitory concentration: 19500 nM
Compound 3: the middle estimate sits 1.3-fold (0.11 log units) below what was measured; measured number inside the range.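

Moving from 2-(trifluoromethoxy)phenyl to 3-fluorophenyl on the aromatic nitrogen gives an at least 2.0-fold lower number from compound 2 to compound 3 (0.31 log units; beyond the scatter) in this assay, so the number responds to the group at this position. Compound 2 gives only a limit, so the true size of this step stays unknown: the limit of > 40000 nM in this assay, at which 1 of the 3 values shown sits.

With 3-fluorophenyl kept, changing the group on the oxygen gives a 2.0-fold higher number from compound 1 to compound 3 (0.31 log units; beyond the scatter), so that end of the molecule also moves the number.

From the compounds shown here alone, both the substituent and its place on the phenyl ring changed, so the contribution of each remains open. A plain phenyl group or an aminophenyl group on that nitrogen could help separate them.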